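A Halogen Swap on the Sulfonamide Ring

This account rests on a few compounds, and the source may have more. Where it says the series, first, only, none or still open, it means among the compounds named here.

Compound 1 `O=C(c1ccc(OCCCN2CC[C@H](NS(=O)(=O)c3cccc(F)c3)C2)cc1)C1CC1` and compound 2 `CC(=O)c1ccc(OCCCN2CC[C@H](NS(=O)(=O)c3ccc(C#N)cc3)C2)cc1` share one core and differ only in the aryl group carried by the sulfonamide. In an assay on isolated protein for binding affinity to histamine H2 receptor (Homo sapiens) (on this read-out higher numbers stand for weaker inhibition and lower numbers for stronger inhibition), compound 1 gives 1600 nM, and compound 2 gives 2300 nM. Compound 1 has the lowest of the two numbers, yet its gap to compound 2 lies within the usual scatter, so this assay does not set the two apart. Compound 3 `O=C(c1ccc(OCCCN2CC[C@H](NS(=O)(=O)c3ccc(Cl)cc3)C2)cc1)C1CC1` keeps everything of compound 1 except one group: 4-chlorophenyl in place of 3-fluorophenyl on a sulfonyl sulfur. Within the data shown here, no measured pair shows the effect of this particular change, so the only guide is that both numbers in hand sit in the same range. For compound 3 no movement beyond the scatter is expected, a 1.2-fold lower number from compound 1 to compound 3 (0.09 log units; within the scatter). Compound 3 is therefore estimated at 1300 nM, with a range from 500 nM to 3500 nM.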

Compound 3, inhibition constant: 290 nM
Compound 3: middle estimate off by 4.5-fold (0.65 log units), on the high side, outside the stated range (below it).
By their numbers in this assay, from the lowest: compound 3; then compounds 1 and 2 (each within the scatter of the next).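

Swapping 3-fluorophenyl for 4-chlorophenyl on a sulfonyl sulfur, with the rest of the molecule unchanged, gives in this assay a 5.5-fold lower number from compound 1 to compound 3 (0.74 log units; beyond the scatter), a modest step but one beyond the scatter. Among these compounds, this is the first single-place comparison here, and it shows that the group on the sulfonyl sulfur can shift the number in this read-out, something compounds 1 and 2 could not show with their values within the scatter of each other. Nothing available explains why this swap moves the number.

The two groups differ both in their halogen and in the number in their names, so the step cannot be assigned to either difference alone. As far as these compounds go, what a plain phenyl, a methoxyphenyl or a pyridine ring would give on the same sulfonyl sulfur also remains open.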